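This account rests on a few compounds, and the source may have more. Where it says the series, first, only, none or still open, it means among the compounds named here.

Compound 1 `O=S(=O)(NCCCCNCc1ccc(Br)cc1)c1cc(C(F)(F)F)cc(C(F)(F)F)c1` and compound 2 `O=S(=O)(NCCCNCc1cccc2ccccc12)c1cc(C(F)(F)F)cc(C(F)(F)F)c1` share the same core and differ in the length of the saturated chain and in the aromatic group carried at its end. In a functional assay on MIA PaCa-2 cells (Homo sapiens) for inhibition, read by MTT assay, with a stated time of 72 h (a higher number here means a weaker inhibitor of growth, a lower number a stronger inhibitor of growth), compound 1 gives 2100 nM. In this assay compound 2 gives 2800 nM. These two numbers lie within the scatter of one another, so compound 2 stands beside compound 1 rather than apart from it. Compound 3 `O=S(=O)(NCCCNCc1ccc(Cl)cc1)c1cc(C(F)(F)F)cc(C(F)(F)F)c1` has not been measured; it differs from compound 2 by 4-chlorophenyl in place of naphthalen-1-yl on a saturated chain carbon bound to an amine nitrogen. Going by the values given here, no measured pair shows this exact change, so its size cannot be read from data. A step from compound 2 to compound 3 of about a 1.2-fold lower number from compound 2 to compound 3 (0.09 log units; within the scatter) is expected, not beyond the scatter, because compound 1 gives 2100 nM with a related halogen-bearing ring. Compound 3 is therefore expected to give about 2300 nM, within 1000 nM to 5500 nM.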

Compound 3, concentration for 50% growth inhibition: 2800 nM
Beside the measured number, compound 3's estimate is 1.2-fold (0.09 log units) below it; low and high end bracket the measured number.
By their numbers in this assay, from the lowest: compounds 1, 2 and 3 (each within the scatter of the next).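

In this assay, the change from naphthalen-1-yl to 4-chlorophenyl removes one of the two aromatic rings, yet the step is no change at the digits printed from compound 2 to compound 3 (within the scatter) and shows no difference that can be read at this position. The step of a 1.3-fold higher number from compound 1 to compound 3 (0.12 log units; within the scatter) also stays within the usual scatter, but it alters the chain and the halogen together, so it cannot assign an effect to either one. Nothing available explains why these values lie so close.

The compounds shown leave open the effect of chain length alone, with the aromatic group held the same. They also leave open whether a pyridine ring, a methoxy group on the ring or a longer chain would separate from this group of values.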